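The source may hold more compounds than are shown below. What is called first, only, known or untested is meant among the compounds shown, and "the series" means these compounds.

Measured compounds:
compound 1, `COc1ccc(CN(C(=O)CSc2nc3ccccc3s2)c2cc(OC)c(OC)c(OC)c2)cc1F`: 1830 nM
compound 2, `COc1cc(CN(C(=O)CSc2nc3ccccc3s2)c2cc(OC)c(OC)c(OC)c2)cc(OC)c1OC`: 65300 nM

In a functional assay on HCT-116 cells (Homo sapiens) for antiproliferative activity, read by MTT assay, with a stated time of 48 h (a higher number here means a weaker inhibitor, a lower number a stronger inhibitor), compound 1 stands lowest of the two numbers; the nearest is compound 2, reached by a 36-fold higher number from compound 1 to compound 2 (1.55 log units; beyond the scatter). Compound 3, `COc1ccc(CN(C(=O)CSc2nc3ccccc3s2)c2cc(OC)c(OC)c(OC)c2)cc1N=[N+]=[N-]`, differs from compound 1 by azido in place of fluoro on an aromatic carbon. No measured step touches this position; the only step shown, from compound 1 to compound 2, changes a different part and gives no guide to the size or direction here. The expectation is therefore a small shift at most, a 1.4-fold higher number from compound 1 to compound 3 (0.14 log units; within the scatter). Compound 3 is estimated at 2500 nM in this assay, with a range of 600 nM to 12000 nM.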

Compound 3, half-maximal inhibitory concentration: 2860 nM
Estimate against measurement, compound 3: 1.1-fold (0.06 log units) below, within the range that was stated.
By their numbers in this assay, from the lowest: compounds 1 and 3 (each within the scatter of the next); then compound 2.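

In this assay, this aromatic carbon, ortho to a methoxy group, takes azido with 3 heavy atoms in place of fluoro with 1 heavy atom at only a 1.6-fold higher number from compound 1 to compound 3 (0.19 log units; within the scatter). The 3-azido-4-methoxyphenyl group stays well apart from the 3,4,5-trimethoxyphenyl group, with a 23-fold lower number from compound 2 to compound 3 (1.36 log units; beyond the scatter), so the gap first seen with the fluoro compound also appears with azido. No available data bear on the reason for either result. Open, from the compounds shown here alone, is how an amine, a hydroxy group or a bare hydrogen on this carbon would compare with fluoro and azido.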